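Piperazine in Place of Aminopiperidine: Expected Cytotoxicity

A few compounds are considered here, and "the series" means these few. Any claim that something is new, unique, unknown or untested is made for them only; others in the source may bear on it.

In an ADME assay on MT4 cells (Homo sapiens) for cytotoxicity, read by MTT assay, with a stated time of 5 days (on this read-out higher numbers stand for lower toxicity in this test and lower numbers for higher toxicity in this test), the measured compounds gave:
Compound 1 `Cc1cc(/C=C/C#N)cc(C)c1Oc1nc(Nc2ccc(CN3CCNCC3)cc2)nc2ccsc12`: 3970 nM
Compound 2 `Cc1cc(/C=C/C#N)cc(C)c1Oc1nc(Nc2ccc(N3CCCC(N)C3)cc2)nc2ccsc12`: 3820 nM
Compound 3 `Cc1cc(/C=C/C#N)cc(C)c1Oc1nc(Nc2ccc(N3CCCC(NS(N)(=O)=O)C3)cc2)nc2sccc12`: a limit only, > 217000 nM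

Compound 2 holds the lower of the two plain numbers, but the step of a 1.0-fold lower number from compound 1 to compound 2 (0.02 log units; within the scatter) is within the scatter, so the two cannot be told apart. For compound 3 only a limit is known, (the limit of > 217000 nM in this assay, at which 1 of the 3 values shown sits).

Compound 4 `Cc1cc(/C=C/C#N)cc(C)c1Oc1nc(Nc2ccc(N3CCNCC3)cc2)nc2ccsc12` differs from compound 2 by piperazin-1-yl in place of 3-aminopiperidin-1-yl on an aromatic carbon. For the measured compounds named here, the single measured step that bears on this change, a 1.0-fold lower number from compound 1 to compound 2 (0.02 log units; within the scatter), also exchanged a piperazine-bearing group for the aminopiperidine and stayed within the scatter. No step beyond the scatter is therefore expected in this assay for compound 4. Compound 4 is estimated at 3900 nM, with a range from 1500 nM to 10000 nM. The expected step is a 1.0-fold higher number from compound 2 to compound 4 (0.01 log units; within the scatter).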

Compound 4, half-maximal cytotoxic concentration: 5730 nM
The estimate for compound 4 lay 1.5-fold (0.17 log units) below the measured number, and the stated range covers the measured number.
By their numbers in this assay, from the lowest: compounds 2, 1 and 4 (each within the scatter of the next). At a limit, above all of these: compound 3.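

In this assay, piperazin-1-yl placed directly on the aromatic carbon gives a 1.5-fold higher number from compound 2 to compound 4 (0.18 log units; within the scatter). Set against the same ring attached through a methyl link, it gives a 1.4-fold higher number from compound 1 to compound 4 (0.16 log units; within the scatter). These three groups therefore cannot be told apart at this position, and no measurement shown offers a reason for these numbers.

As far as these compounds go, it remains open whether a morpholine, a carboxylic acid or a longer chain ending in an amine at this position would stay within the same scatter or move the number beyond it.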